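Swapping fluoro for chloro in a HepG2 cytotoxicity series

The source may report more compounds than this note shows. Statements on the series, on what has been measured and on what is new or still open speak of the compounds shown alone.

Compound 1 `Cc1ccc(S(=O)(=O)N[C@@H](CC(=O)NC(C)(C)C)C(=O)NCCNC(=O)c2ccccc2F)cc1` gives > 11000 nM (a limit)
Compound 2 `Cc1ccc(S(=O)(=O)N[C@@H](CC(=O)NC(C)(C)C)C(=O)NCCNC(=O)c2ccc(F)cc2)cc1` gives > 11000 nM (a limit)

In an ADME assay on HepG2 cells (Homo sapiens) for cytotoxicity (on this read-out lower numbers stand for an effect already at smaller amounts and higher numbers for an effect only at larger amounts of compound), compound 2 reports > 11000 nM as a limit and not as a number. The whole record so far is the limit of > 11000 nM in this assay, at which 2 of the 2 values shown sit, and no exact value exists yet. Compound 3 `Cc1ccc(S(=O)(=O)N[C@@H](CC(=O)NC(C)(C)C)C(=O)NCCNC(=O)c2ccc(Cl)cc2)cc1` keeps the rest of compound 2 and carries chloro in place of fluoro on an aromatic carbon, para to a large group, as chloro in place of fluoro on an aromatic carbon sets out. Among the compounds with values here, the only measured step in this part of the molecule is a step that the two limits leave unreadable from compound 1 to compound 2 and it offers no size to carry over, so no step beyond the scatter is expected in this assay and no direction is favoured. The expected change is a step that the limit leaves unreadable from compound 2 to compound 3 and it remains a rough expectation. Compound 3 is estimated at 16000 nM with a range from 8000 nM to 32000 nM and is expected to possibly yield only a limit again.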

Compound 3, half-maximal effective concentration: > 11000 nM
Compound 3 was reported as a limit; the forecaster's own chance of this, stated with the estimate: 85%; the middle value does not contradict the limit.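

In this assay compound 3 gives > 11000 nM as a limit and not a number. Compound 1 and compound 2 sit at the same limit, so no step among these three compounds can be read: the limit of > 11000 nM in this assay, at which 3 of the 3 values shown sit. The compounds shown leave open at what exact value any of them acts in this cell test, and whether chloro and fluoro differ there at all.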